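Fluoro to methoxy on a compound at the limit

This account rests on a few compounds, and the source may have more. Where it says the series, first, only, none or still open, it means among the compounds named here.

Of the compounds shown here, three have been read in a functional assay on A549 cells (Homo sapiens) for cytotoxicity, read by WST assay, with a stated time of 48 h (on this read-out lower numbers stand for stronger inhibition and higher numbers for weaker inhibition), so far. Among the compounds with values here, compound 3 (`COc1ccc(-c2[nH]c3ccccc3c2/C=C(\C#N)C(=O)c2c[nH]c3ccccc23)cc1`) gives 3000 nM and is the only one with a measured number. Compound 1 (`COc1ccc2[nH]cc(C(=O)/C(C#N)=C/c3c[nH]c4cc(F)ccc34)c2c1`) gives > 50000 nM, which is a limit of the assay and not a number. Compound 2 (`N#C/C(=C\c1cn(Cc2ccc(Cl)cc2)c2ccccc12)C(=O)c1c[nH]c2cc(F)ccc12`) gives > 50000 nM, also only a limit. On these data alone, compound 2 therefore stands at the limit of > 50000 nM in this assay, at which 2 of the 3 values shown sit, and its true position is unknown.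

Compound 4 (`COc1ccc2c(C(=O)/C(C#N)=C/c3cn(Cc4ccc(Cl)cc4)c4ccccc34)c[nH]c2c1`) differs from compound 2 by methoxy in place of fluoro on an aromatic carbon. Within the data shown here, no measured pair isolates this change. Compound 1 also carries a methoxy and still reads only as a limit in this assay, so no large gain is expected from the swap. The an at least 1.6-fold lower number from compound 2 to compound 4 (0.22 log units; that floor lies within the scatter) is expected to be small, with any movement towards stronger inhibition. Compound 4 is estimated at 30000 nM, with an expected range of 8000 nM to 50000 nM, and a reading at the limit remains about as likely as a number.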

Compound 4, half-maximal inhibitory concentration: > 50000 nM
Compound 4 gave a limit, no number (the forecaster's own chance of this, stated with the estimate: 50%); at least 1.6-fold (0.22 log units) between middle value and limit.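

Compound 2 and compound 4 are both limits and not numbers, so no step for methoxy in place of fluoro can be read between them: the limit of > 50000 nM in this assay, at which 3 of the 4 values shown sit.

The compounds shown leave open whether this swap changes inhibition at all, and where the true values of compound 2 and compound 4 lie.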